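A Methyl on the Aryl Amine in a Writhing Test

This account rests on a few compounds, and the source may have more. Where it says the series, first, only, none or still open, it means among the compounds named here.

Compound 1 `CN(CC1CCC/C(=C\c2ccccc2)C1=O)c1ccccc1`, compound 2 `Cc1ccc(N(C)CC2CCC/C(=C\c3ccccc3)C2=O)cc1` and compound 3 `COc1ccc(C2(O)/C(=C/c3ccc(C)cc3)CCCC2CN(C)c2ccccc2)cc1` have been tested in a functional assay on the whole organism (strain Kunming) for inhibition, with Mus musculus as the target, in the writhing test, with stated times of 1 h and 15 min, at a dose of 200 mg/kg by the oral route; on this read-out higher numbers stand for more inhibition at the one dose given (going by the name of the read-out) and lower numbers for less inhibition. In this assay compound 1 gives 69.7%, compound 2 gives 81% and compound 3 gives 72.1%. Compound 1 and compound 2 differ in a single place, (methyl in place of hydrogen on an aromatic carbon), and this change brought a number 11.3 percentage points higher from compound 1 to compound 2 (beyond the scatter). The values of compound 1 and compound 3 lie within the scatter of each other, and the difference between their two cores is not broken down here.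

Compound 4 `COc1ccc(C2(O)/C(=C/c3ccc(C)cc3)CCCC2CN(C)c2ccc(C)cc2)cc1` has not yet been measured. It differs from compound 3 by methyl in place of hydrogen on an aromatic carbon, and the place of the change is described in the same words as for the earlier pair, so this is the same change made on another core. Among the measured compounds shown here, the only guide to its effect is compound 2, whose step a number 11.3 percentage points higher from compound 1 to compound 2 (beyond the scatter) was modest but beyond the scatter. A step of about that size is expected again, a number 7.9 percentage points higher from compound 3 to compound 4 (within the scatter). On that basis compound 4 is estimated at 80%, with a likely range from 68% to 92%.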

Compound 4, a percentage reported as inhibition, in the whole organism at one dose (the size of the read-out at that dose, not a potency): 62.2%
For compound 4 the middle estimate is 17.8 percentage points above the measured one; measured number below the stated range.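

Replacing phenyl with 4-methylphenyl on the amine gave a number 9.9 percentage points lower from compound 3 to compound 4 (within the scatter), so the gain seen on the first core did not reappear on the second. The two steps in this assay do not agree: the same change on two cores in this assay, a number 11.3 percentage points higher (beyond the scatter) from compound 1 to compound 2 and a number 9.9 percentage points lower (within the scatter) from compound 3 to compound 4, 21.2 percentage points apart, beyond the scatter of two such steps. In these two pairs, then, the outcome of this methyl depends on the core it is placed on, but two pairs at a single dose do not show which feature of the cores is responsible, and the step on the second core alone cannot be called a real fall.

The compounds shown leave open whether a different group on the same aromatic carbon, such as a chlorine atom or a carboxylic acid, would also act differently on the two cores. Among the compounds shown here, it also remains open which of the several differences between the cores matters, since no pair here changes only one of them.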